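A few compounds are considered here, and "the series" means these few. Any claim that something is new, unique, unknown or untested is made for them only; others in the source may bear on it.

Among the measured compounds shown here, compound 2 `O=C(CCCCCCc1ccccc1)c1ncc(C(=O)N2CCOCC2)o1` holds the higher of the two numbers so far obtained in an assay (Rattus norvegicus) for inhibition of Fatty-acid amide hydrolase 1 (Homo sapiens); on this read-out higher numbers stand for weaker inhibition and lower numbers for stronger inhibition: compound 2 gives 24 nM, whereas compound 1 `Cc1cccc(-c2cnc(C(=O)CCCCCCc3ccccc3)o2)n1` gives 3.3 nM, the change between them being a 7.3-fold higher number from compound 1 to compound 2 (0.86 log units; beyond the scatter). Compound 3 `O=C(CCCCCCc1ccccc1)c1ncc(C(=O)N2CCSCC2)o1` is yet to be measured in this assay. It differs from compound 2 in one place: thiomorpholin-4-yl in place of morpholin-4-yl on a carbonyl carbon. For the measured compounds named here, the single measured step exchanged a group on an aromatic carbon rather than the ring attached to the carbonyl carbon, so no measured step bears directly on the present exchange, and the data give no indication of a shift in either direction. The expected step is therefore no change at the digits printed from compound 2 to compound 3 (within the scatter), that is, none beyond the scatter. Compound 3 is accordingly estimated at 24 nM in this assay, with a range from 10 nM to 60 nM.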

Compound 3, inhibition constant: 10 nM
For compound 3 the middle estimate is 2.4-fold (0.38 log units) above the measured one; the range from low to high includes it.
By their numbers in this assay, from the lowest: compound 1; then compound 3; then compound 2.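

In this assay, among the compounds shown here, the first measured exchange on this carbonyl carbon shows that the ring there affects the number: thiomorpholin-4-yl in place of morpholin-4-yl gives a 2.4-fold lower number from compound 2 to compound 3 (0.38 log units; beyond the scatter), a modest step beyond the scatter between two rings that differ only in one hetero atom. The exchange does not close the gap to the 6-methylpyridin-2-yl group, since (thiomorpholin-4-yl)carbonyl in its place still gives a 3.0-fold higher number from compound 1 to compound 3 (0.48 log units; beyond the scatter), and compound 1 keeps the lowest number of the three. Nothing available explains why the sulfur-containing ring gives the lower number.

The compounds shown leave open whether the step depends on sulfur itself or would also appear with a piperidin-1-yl ring, which has carbon at that ring position. They also leave open how an open-chain amine such as dimethylamino would behave on the same carbonyl carbon.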